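Amide substituent at the carbonyl carbon: phenethyl to cyclobutyl

A few compounds are considered here, and "the series" means these few. Any claim that something is new, unique, unknown or untested is made for them only; others in the source may bear on it.

Among the compounds with values here, compound 2 `O=C(CCc1ccccc1)NCCCNc1nc(Nc2cccc(F)c2)ncc1Br` gives the higher of the two numbers so far; in an assay on isolated protein for inhibition of serine/threonine-protein kinase TBK1 (Homo sapiens) (on this read-out lower numbers stand for stronger inhibition and higher numbers for weaker inhibition), compound 2 gives 560 nM, while compound 1 `O=C(NCCCNc1nc(Nc2cccc(F)c2)ncc1Br)c1cccs1` gives 9 nM. The change to compound 3 `O=C(NCCCNc1nc(Nc2cccc(F)c2)ncc1Br)C1CCC1` is cyclobutyl in place of phenethyl on a carbonyl carbon. Within the data shown here, the one measured step at the same position, a 62-fold higher number from compound 1 to compound 2 (1.79 log units; beyond the scatter), shows that this amide substituent moves the read-out strongly, though neither of those groups resembles cyclobutyl. For compound 3 a step toward lower numbers, a 3.7-fold lower number from compound 2 to compound 3 (0.57 log units; beyond the scatter), is expected, with wide uncertainty. Compound 3 is estimated at 150 nM, range 30 nM to 800 nM.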

Compound 3, half-maximal inhibitory concentration: 2 nM
The estimate for compound 3 lay 75-fold (1.88 log units) above the measured number, outside the stated range (below it).
By their numbers in this assay, from the lowest: compound 3; then compound 1; then compound 2.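

At this carbonyl carbon, an aromatic ring is not needed for a low number: cyclobutyl, with no aromatic ring, gives a 4.5-fold lower number from compound 1 to compound 3 (0.65 log units; beyond the scatter) and so improves on thiophen-2-yl. The change from phenethyl is much larger, a 280-fold lower number from compound 2 to compound 3 (2.45 log units; beyond the scatter) and places the group of 4 heavy atoms lowest of the three and the group of 8 highest. No evidence is available that accounts for either step.

Open, as far as these compounds go, is whether cyclopropyl or cyclopentyl would hold the low number, and whether a cyclobutyl ring carrying an amine would keep it. Also open, from the compounds shown here alone, is whether a plain propyl chain would track phenethyl or cyclobutyl.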